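The source may report more compounds than this note shows. Statements on the series, on what has been measured and on what is new or still open speak of the compounds shown alone.

Working notes on the series. Three compounds have numbers in a functional assay on CHO-K1 cells for antagonist activity at C-X-C chemokine receptor type 3 (Homo sapiens), read by FLIPR, with a stated time of 10 min (a higher number here means a weaker inhibitor, a lower number a stronger inhibitor), so far. Compound 1 `Cn1c(CN2CCN(c3ccccc3NC(=O)c3ccco3)CC2)nc2ccccc21` gives 372 nM in this assay and stands well apart from the other two. Compound 2 `COc1ccc(-c2nc(C(F)(F)F)sc2N2CCN(C(=O)Cn3cnc4cccnc43)[C@H](C)C2)cc1` gives 13 nM in this assay, and compound 3 `COc1ncc(-c2nc(C(F)(F)F)sc2N2CCN(C(=O)Cn3cnc4cccnc43)[C@H](C)C2)cn1` gives 3.8 nM in this assay. Compound 3 therefore carries the lowest number of the three, with compound 2 nearest to it and compound 1 furthest away. For the measured compounds named here, the only single-point step measured so far is a 3.4-fold lower number from compound 2 to compound 3 (0.53 log units; beyond the scatter), made by 2-methoxypyrimidin-5-yl in place of 4-methoxyphenyl on an aromatic carbon.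

Compound 4 `CCCc1ncc(-c2nc(C(F)(F)F)sc2N2CCN(C(=O)Cn3cnc4cccnc43)[C@H](C)C2)cn1` is not yet measured. It differs from compound 3 in one place: propyl in place of methoxy on an aromatic carbon. Going by the values given here, no measured step exchanges methoxy for propyl anywhere, so there is no direct precedent; the one measured step concerns the ring itself rather than the group on it, and it only sets the scale of what a single change has done here so far. With nothing pointing clearly either way, the step of a 1.6-fold higher number from compound 3 to compound 4 (0.20 log units; within the scatter) is expected to be small, possibly within the scatter. For compound 4 the estimate in this assay is 6 nM, within a range of 2 nM to 20 nM.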

Compound 4, half-maximal inhibitory concentration: 3.3 nM
Compound 4: the middle estimate sits 1.8-fold (0.26 log units) above what was measured; the measured number falls inside the stated range.
By their numbers in this assay, from the lowest: compounds 4 and 3 (each within the scatter of the next); then compound 2; then compound 1.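

In this assay, the aromatic carbon between two ring nitrogen atoms, para to a large group, accepts propyl in place of methoxy with a 1.2-fold lower number from compound 3 to compound 4 (0.06 log units; within the scatter), so at this position the number does not depend on keeping methoxy, with its oxygen and its hydrogen-bond acceptor, since propyl has neither. The change from 4-methoxyphenyl to 2-propylpyrimidin-5-yl gives a 3.9-fold lower number from compound 2 to compound 4 (0.60 log units; beyond the scatter), so the step beyond the scatter seen with 2-methoxypyrimidin-5-yl, a 3.4-fold lower number from compound 2 to compound 3 (0.53 log units; beyond the scatter), also appears with a different group at this position, and on these three compounds the two pyrimidine-bearing compounds share the lower numbers. No measurement on hand explains why methoxy and propyl read alike here, and the result stands as an observation only.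

The compounds shown leave open how far this position stays permissive: a longer chain such as pentyl, an amine or a carboxylic acid in the same place could hold the number or move it well beyond the scatter. They also leave open whether propyl would serve equally on the phenyl ring of compound 2, so the contribution of the ring and that of its group remain unseparated.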